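A Halogen Swap on the Aryl Ring of Compound 3

This account rests on a few compounds, and the source may have more. Where it says the series, first, only, none or still open, it means among the compounds named here.

Of the compounds shown here, three sharing one core have been measured in a functional assay on C6 cells (Rattus norvegicus) for cytotoxicity, read by MTT assay, with a stated time of 24 h, tested at 12 ug/mL; on this read-out higher numbers stand for a weaker effect at the one concentration tested and lower numbers for a stronger effect. Compound 1 `Cc1nnc(SCC(=O)N/N=c2/scc(-c3ccc(F)cc3)n2-c2ccccc2)s1` gives 73.7%, compound 2 `O=C(CSc1nnnn1-c1ccccc1)N/N=c1/scc(-c2ccc(Cl)cc2)n1-c1ccccc1` gives 69.3%, and compound 3 `O=C(CSc1ncccn1)N/N=c1/scc(-c2ccc(Cl)cc2)n1-c1ccccc1` gives 91.6%. For the measured compounds named here, on these numbers compound 3 stands highest of the three, its nearest neighbour being compound 1, and the only single-site step recorded, a number 22.3 percentage points higher from compound 2 to compound 3 (beyond the scatter), is a modest rise that comes from exchanging the group on the sulfur, not from any change on the aromatic ring.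

Compound 4 `O=C(CSc1ncccn1)N/N=c1/scc(-c2ccc(F)cc2)n1-c1ccccc1` is not yet measured. It differs from compound 3 in one place: fluoro in place of chloro on an aromatic carbon. Going by the values given here, no measured pair isolates this fluoro-for-chloro exchange, since compound 1 and compound 2 differ from each other at two sites and their values, which lie within the usual scatter of one another, cannot be read as a halogen effect. Among the compounds with values here, with no bearing step in hand, the expectation for compound 4 rests on compound 3 alone, and the step of a number 3.6 percentage points lower from compound 3 to compound 4 (within the scatter) is expected to stay within the scatter. Compound 4 is therefore estimated at 88%, with a range from 74% to 100%.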

Compound 4, a percentage reported as activity, at one concentration (the size of the read-out at that concentration, not a potency): 77.4%
Beside the measured number, compound 4's estimate is 10.6 percentage points above it, within the range that was stated.
By their numbers in this assay, from the lowest: compounds 2, 1 and 4 (each within the scatter of the next); then compound 3.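

In this assay, for the compounds shown here, the step of a number 14.2 percentage points lower from compound 3 to compound 4 (beyond the scatter) is the first single-site reading on the aromatic ring, and it shows that this position is not silent: exchanging chloro for fluoro gives a lower number, which here stands for a stronger effect at the one concentration tested. Going by these compounds alone, with the 4-fluorophenyl group held constant, the step of a number 3.7 percentage points higher from compound 1 to compound 4 (within the scatter) adds a first comparison of pyrimidin-2-yl with 5-methyl-1,3,4-thiadiazol-2-yl on the sulfur, and these two groups are not told apart by this read-out. Nothing given here accounts for the effect of the halogen exchange.

The compounds shown leave open whether the same halogen exchange would move the number similarly with 1-phenyl-1H-tetrazol-5-yl or 5-methyl-1,3,4-thiadiazol-2-yl on the sulfur, since it is read only with pyrimidin-2-yl there. They also leave open how bromo, methoxy, an amine or plain hydrogen at this place on the ring would compare with fluoro and chloro, and whether the step would hold at other concentrations.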